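Hydroxy to 3-aminopropyl on the amide side chain

A few compounds are considered here, and "the series" means these few. Any claim that something is new, unique, unknown or untested is made for them only; others in the source may bear on it.

Compound 1 `O=C(O)[C@@H]1CCCN1C(=O)CN(c1nc(Cl)nc2[nH]cnc12)C1CC1` gives 23.6% in a functional assay on the whole organism (Tail, strain ICR) with Mus musculus as the target, in the tail flick test, with a stated time of 120 min, at a dose of 25 umol/kg by the oral route; on this read-out higher numbers stand for a stronger effect at the one dose given and lower numbers for a weaker effect.
Compound 2 `O=C(CN(c1nc(Cl)nc2[nH]cnc12)C1CC1)N[C@@H](CO)C(=O)O` gives 39% in this assay.
Compound 3 `O=C(CN(c1ncnc2c1ncn2C1CCCCO1)C1CC1)N[C@@H](CC(=O)OCc1ccccc1)C(=O)OCc1ccccc1` gives 7.82% in this assay.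

Among the compounds with values here, compound 2 stands highest of the three numbers; its nearest neighbour is compound 1, where the single measured step, a number 15.4 percentage points higher from compound 1 to compound 2 (beyond the scatter), lies beyond the scatter, and compound 3 sits further down. Compound 4 `NCCCC[C@H](NC(=O)CN(c1nc(Cl)nc2[nH]cnc12)C1CC1)C(=O)O` differs from compound 2 by 3-aminopropyl in place of hydroxy on a saturated chain carbon, two bonds along the chain from an amide-type nitrogen and a carbonyl carbon. Within the data shown here, no measured step covers a change of this kind, so the only anchor is the number for compound 2 itself. For compound 4 the step of a number 3 percentage points lower from compound 2 to compound 4 (within the scatter) is therefore expected to stay within the scatter, in this assay with no clear direction. Compound 4 is estimated at 36%, in a range from 15% to 58%.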

Compound 4, a percentage reported as activity, at one dose (the size of the read-out at that dose, not a potency): 16.4%
Estimate against measurement, compound 4: 19.6 percentage points above; the range from low to high includes it.
By their numbers in this assay, from the lowest: compounds 3, 4 and 1 (each within the scatter of the next, the first and the last beyond it); then compound 2.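

The side chain on this saturated chain carbon matters: with 3-aminopropyl in place of hydroxy, a number 22.6 percentage points lower from compound 2 to compound 4 (beyond the scatter) in this assay. The earlier step changed the whole amino acid unit, whereas this one changes a single group on an otherwise identical structure, and the fall is of modest size. Nothing offered here accounts for the fall. On these data alone, whether it follows the terminal amine or the longer chain stays open. A plain butyl chain, a shorter aminoethyl chain or a carboxylic acid at this place would help to tell these apart.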